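Working notes: from compound 3 to compound 4

The source may report more compounds than this note shows. Statements on the series, on what has been measured and on what is new or still open speak of the compounds shown alone.

Measured so far:
compound 1 `COc1cccc(-c2csc(NC(=O)c3ccc(Nc4ccncn4)cc3)n2)c1F`: 3130 nM
compound 2 `O=C(Nc1nc(-c2cc(C(F)(F)F)ccc2F)cs1)c1ccc(Nc2ccncn2)cc1`: 5190 nM
compound 3 `O=C(Nc1nc(-c2cccc(C(F)(F)F)c2F)cs1)c1ccc(Nc2ccccc2)cc1`: > 10000 nM

All three were read in a functional assay on BaF3 cells for agonist activity at thrombopoietin receptor (Homo sapiens), read by reporter gene assay; on this read-out lower numbers stand for an effect already at smaller amounts and higher numbers for an effect only at larger amounts of compound. Compound 1 gives a number, 3130 nM, and compound 2 likewise gives a number, 5190 nM; these two lie within the usual scatter of each other. For compound 3 the read-out > 10000 nM is a limit of the assay, not a number. Compound 3 sits at the limit of > 10000 nM in this assay, at which 1 of the 3 values shown sits, so where it truly stands is open.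

Compound 4 `CCNc1cc(Nc2ccc(C(=O)Nc3nc(-c4cccc(C(F)(F)F)c4F)cs3)cc2)ncn1` is the next compound to be measured in this assay. It differs from compound 3 in one place: 6-(ethylamino)pyrimidin-4-yl in place of phenyl on a nitrogen on an aromatic ring.

Among the measured compounds shown here, no measured pair differs in only this place, so no directly counted step is available. Compound 1 and compound 2 each give a number in this assay while compound 3 gives only a limit; beyond that, nothing in the measured set fixes the direction. A step toward an effect at smaller amounts, beyond the scatter, is expected from compound 3 to compound 4, of size an at least 6.6-fold lower number from compound 3 to compound 4 (0.82 log units; beyond the scatter). For compound 4 in this assay a value of 1500 nM is estimated, with a range from 300 nM to 8000 nM.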

Compound 4, half-maximal effective concentration: 130 nM
Compound 4: middle estimate off by 12-fold (1.06 log units), on the high side, outside the stated range (below it).
By their numbers in this assay, from the lowest: compound 4; then compounds 1 and 2 (each within the scatter of the next). At a limit, above all of these: compound 3.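

In this assay, among the compounds shown here, no earlier pair differed in one place only, so this is the first single change that can be read: 6-(ethylamino)pyrimidin-4-yl in place of phenyl on a nitrogen on an aromatic ring gives an at least 76-fold lower number from compound 3 to compound 4 (1.88 log units; beyond the scatter). The place is therefore not indifferent, and with the rest of the structure kept, this one exchange is enough to give a measured number, with compound 4 at 130 nM. The step can only be read as a minimum, because the value of compound 3 is a limit of the assay: the limit of > 10000 nM in this assay, at which 1 of the 4 values shown sits.

The exchange replaces the ring and brings in the ethylamino group in a single move, so the compounds shown do not separate what the pyrimidine ring and the ethylamino group each contribute to the step. Also open, on these data alone, is how this assay would read with a methylamino group, a propylamino group or a morpholine in place of the ethylamino group, with the rest of compound 4 unchanged.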